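The compounds below may be only part of what the source reports. "The series", "measured", "known", "first", "only" and "open" are said of these compounds alone.

Measured in a functional assay on NALM-6 cells (Homo sapiens) for cytotoxicity, with a stated time of 72 h; on this read-out lower numbers stand for an effect already at smaller amounts and higher numbers for an effect only at larger amounts of compound:
compound 1 `C=C[C@@](C)(/C=C/c1ccc(OC)cc1)CCC=C(C)C`: > 43400 nM
compound 2 `C=C[C@@](C)(/C=C/c1ccc(Nc2ccc(OC)cc2)cc1)CCC=C(C)C`: > 43400 nM
compound 3 `C=C[C@@](C)(/C=C/c1ccc(Nc2ccc(F)cc2)cc1)CCC=C(C)C`: > 43400 nM

Each of these entries is a limit of the assay and not a number. Among the compounds with values here, the series so far shows (the limit of > 43400 nM in this assay, at which 3 of the 3 values shown sit). Compound 3 therefore has no number of its own and stands with the other two compounds.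

The next structure is compound 4 `C=C[C@@](C)(/C=C/c1ccc(Nc2cc(F)cc(F)c2)cc1)CCC=C(C)C`, and the change is 3,5-difluorophenyl in place of 4-fluorophenyl on a nitrogen on an aromatic ring. In words, 3,5-difluorophenyl replaces 4-fluorophenyl on a nitrogen on an aromatic ring.

The closest measured change is a step that the two limits leave unreadable from compound 2 to compound 3. The other two are a step that the two limits leave unreadable from compound 1 to compound 3 and a step that the two limits leave unreadable from compound 1 to compound 2. Within the data shown here, none of them has a readable size, so the series offers no measured step to carry over.

No step beyond the usual scatter is expected in this assay, and no direction can be assigned because of the limit of > 43400 nM in this assay, at which 3 of the 3 values shown sit. The expected change is a step that the limit leaves unreadable from compound 3 to compound 4. For compound 4 the estimated value is 50000 nM, with an expected range from 20000 nM to 100000 nM.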

Compound 4, half-maximal effective concentration: > 43400 nM
Compound 4: a limit, no number (the forecaster's own chance of this, stated with the estimate: 80%); the middle value is on the limit's open side.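

Within the data shown here, compound 4 also gives a limit and not a number in this assay, so no step linking it to compound 1, compound 2 or compound 3 can be read: the limit of > 43400 nM in this assay, at which 4 of the 4 values shown sit. The compounds shown leave open how these groups on the shared core rank against one another in this assay and whether any of them has a measurable effect there.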